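Same Atoms Joined Differently on an Ester-Bearing Amide Side Chain

The source may hold more compounds than are shown below. What is called first, only, known or untested is meant among the compounds shown, and "the series" means these compounds.

Compound 1 `O=C(NCc1ccc(-c2ccccc2)cc1)c1nc[nH]c1C(=O)Nc1ccc(Cl)c(Cl)c1`: 7000 nM
Compound 2 `CC(C)(C)OC(=O)CNC(=O)c1[nH]cnc1C(=O)Nc1ccc(Cl)c(Cl)c1`: 49800 nM

In a functional assay on HL-60 cells (Homo sapiens), with a stated time of 2 days (a lower number here means a stronger inhibitor, a higher number a weaker inhibitor), compound 1 gives 7000 nM, while compound 2 gives 49800 nM. Among the measured compounds shown here, compound 2 thus stands highest of the two numbers; its only neighbour, compound 1, lies well beyond the scatter below it. Compound 3 `COC(=O)[C@@H](NC(=O)c1[nH]cnc1C(=O)Nc1ccc(Cl)c(Cl)c1)C(C)C` keeps the same atoms as compound 2 but joins them differently: 1-(methoxycarbonyl)-2-methylpropyl in place of (tert-butoxycarbonyl)methyl on an amide-type nitrogen. For the measured compounds named here, no step between measured compounds exists to guide this change, so the expectation rests on compound 2 alone. The step is expected to be modest, toward a lower number, and possibly no larger than the scatter: a 1.7-fold lower number from compound 2 to compound 3 (0.22 log units; within the scatter). Compound 3 is therefore expected to give about 30000 nM, somewhere between 8000 nM and 100000 nM.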

Compound 3, half-maximal inhibitory concentration: > 62500 nM
Compound 3 gave a limit, no number; the forecaster's own chance of this, stated with the estimate: 20%; middle value at least 2.0-fold (0.31 log units) away from the limit.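

In this assay compound 3 gave only a limit of the assay, not a number: the limit of > 62500 nM in this assay, at which 1 of the 3 values shown sits. On the amide-type nitrogen, 1-(methoxycarbonyl)-2-methylpropyl in place of (tert-butoxycarbonyl)methyl reads as an at least 1.2-fold higher number from compound 2 to compound 3 (0.09 log units; that floor lies within the scatter). Rearranging the same atoms at this position thus gave no lower number, although the size of the step remains unresolved.

As far as these compounds go, how far the true value of compound 3 lies past its limit stays open. So does whether a carboxylic acid in place of the ester, or an amine on this side chain, would give a lower number.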